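Methoxy in place of hydrogen on the nitrophenyl ether

The source may report more compounds than this note shows. Statements on the series, on what has been measured and on what is new or still open speak of the compounds shown alone.

Measured compounds:
compound 1 `CSc1ccc(OC(C)(C)C2OCC(C/C=C\CCC(=O)O)C(c3cccnc3)O2)c([N+](=O)[O-])c1` 22 nM
compound 2 `CC(C)(Oc1ccccc1[N+](=O)[O-])C1OCC(C/C=C\CCC(=O)O)C(c2cccnc2)O1` < 10 nM

In an assay for inhibition of Thromboxane-A synthase (Homo sapiens), using microsomes (on this read-out lower numbers stand for stronger inhibition and higher numbers for weaker inhibition), compound 1 gives 22 nM. Compound 2 does not give a number in this assay but a limit, < 10 nM, and this is the limit of < 10 nM in this assay, at which 1 of the 2 values shown sits. Among the compounds with values here, the one step that can be read between the two, an at least 2.2-fold lower number from compound 1 to compound 2 (0.34 log units; beyond the scatter), therefore has only a lower bound for its size, and compound 2 stands at the limit of what this assay reports.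

Compound 3 `COc1ccc(OC(C)(C)C2OCC(C/C=C\CCC(=O)O)C(c3cccnc3)O2)c([N+](=O)[O-])c1` differs from compound 2 by methoxy in place of hydrogen on an aromatic carbon. Within the data shown here, the only measured step that bears on this position is the one from compound 1 to compound 2, where a methylsulfanyl group at the same aromatic carbon went with a higher number than hydrogen. Putting a methoxy group there is expected to move the number the other way, back up toward compound 1, by a step of an at least 1.5-fold higher number from compound 2 to compound 3 (0.17 log units; that floor lies within the scatter). For compound 3 the value in this assay is estimated at 15 nM, within a range of 5 nM to 45 nM.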

Compound 3, half-maximal inhibitory concentration: 37 nM
Estimate against measurement, compound 3: 2.5-fold (0.39 log units) below; measured number inside the range.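

In this assay, the aromatic carbon para to a large group and meta to a nitro group now has a second group in place of hydrogen: methoxy gives an at least 3.7-fold higher number from compound 2 to compound 3 (0.56 log units; beyond the scatter), so the higher number seen with methylsulfanyl is not unique to that one group. Compound 2 is reported only as a limit, < 10 nM, and the size of this step is therefore only a floor: the limit of < 10 nM in this assay, at which 1 of the 3 values shown sits. Methoxy in place of methylsulfanyl gives a 1.7-fold higher number from compound 1 to compound 3 (0.23 log units; within the scatter), so in this assay these two groups cannot be told apart at this carbon, and the sulfur of compound 1 shows no distinct effect on the number.

The compounds shown carry only hydrogen, methoxy and methylsulfanyl on this carbon, and they leave open how a fluorine, a hydroxyl or an amine there would read. They also leave open the true value of compound 2, and whether methoxy on another aromatic carbon of the same ring would give a similar step.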